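The source may hold more compounds than are shown below. What is called first, only, known or untested is meant among the compounds shown, and "the series" means these compounds.

Two compounds have been measured in a functional assay on cells for positive allosteric modulation of metabotropic glutamate receptor 2 (Homo sapiens), read by fluorescence and calcium flux, with a stated time of 30 min; on this read-out lower numbers stand for an effect already at smaller amounts and higher numbers for an effect only at larger amounts of compound:

Compound 1, `Brc1ccc(Cn2nnc3c(Br)cccc32)cn1`, gives 210 nM.
Compound 2, `Brc1cccc2c1nnn2CC1CCCC1`, gives 30 nM.

Compound 2 stands at the lower of the two numbers; compound 1 sits above it, and the gap between them lies beyond the scatter of repeated measurements. Within the data shown here, the two differ in more than one place, so no single step can be drawn between them; their values only show that compound 2 gave the effect at smaller amounts than compound 1.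

Compound 3, `CC(C)Cn1nnc2c(Br)cccc21`, has not yet been measured. It differs from compound 2 in one place: isopropyl in place of cyclopentyl on a saturated chain carbon bound to an aromatic nitrogen. Among the measured compounds shown here, no measured pair shows a change of this kind, so the expectation rests on compound 2 and its value of 30 nM alone. A modest rise in the number is expected in this assay, that is an effect only at somewhat larger amounts, though a result still within the scatter of compound 2 would not surprise. The expected step from compound 2 to compound 3 is a 2.7-fold higher number from compound 2 to compound 3 (0.43 log units; beyond the scatter). Compound 3 is therefore estimated at about 80 nM, with a range from 25 nM to 300 nM.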

Compound 3, half-maximal effective concentration: 140 nM
For compound 3 the middle estimate is 1.8-fold (0.24 log units) below the measured one; low and high end bracket the measured number.
By their numbers in this assay, from the lowest: compound 2; then compounds 3 and 1 (each within the scatter of the next).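

The step gives this position its first one-place reading: in this assay, isopropyl in place of cyclopentyl on a saturated chain carbon bound to an aromatic nitrogen brings a 4.7-fold higher number from compound 2 to compound 3 (0.67 log units; beyond the scatter) and so moves the read-out beyond the scatter. The change therefore matters even though both groups consist of carbon only, with no hydrogen-bond donors or acceptors and no net charge on either side. What the pair cannot separate is whether the loss of the ring or the drop from 5 heavy atoms to 3 heavy atoms goes with the rise, and no measurement at hand accounts for it.

Going by these compounds, it remains open whether a cyclohexyl ring, a cyclopropyl ring or a longer chain at this place would give a number near that of compound 2 at 30 nM or one further from it. Also open, on these data alone, is how an amine or a carboxylic acid carried on such a chain would fare on the same core, since every group in the one-place pair here is pure carbon.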